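This account rests on a few compounds, and the source may have more. Where it says the series, first, only, none or still open, it means among the compounds named here.

Among the compounds with values here, compound 2 `O=C(S[C@]12CC[C@@H](O)[C@H]1C(=O)NC2=O)c1ccc(O)cc1` is one of only two compounds measured so far in a functional assay on RAW264.7 cells (Mus musculus) for inhibition, read by Griess assay, with a stated time of 24 h (on this read-out lower numbers stand for stronger inhibition and higher numbers for weaker inhibition), where compound 2 gives 42000 nM and its mirror image, compound 1 `O=C(S[C@@]12CC[C@H](O)[C@@H]1C(=O)NC2=O)c1ccc(O)cc1`, gives 71800 nM in this assay. The step of a 1.7-fold lower number from compound 1 to compound 2 (0.23 log units; within the scatter) is small, and the fact that compounds 1 and 2 differ only in the configuration as drawn is all that separates the two. Compound 3 `O=C(SC12CCC(O)C1C(=O)NC2=O)c1ccc(O)cc1` differs from compound 2 as follows: the two compounds have the same atoms and bonds; at least one stereo element is drawn with a configuration in one of them and without one in the other: 3 of 3 stereo elements differ; a stereocentre at a saturated ring carbon is drawn R in compound 2 and without a configuration in compound 3; a stereocentre at a saturated ring carbon is drawn R in compound 2 and without a configuration in compound 3; a stereocentre at a saturated ring carbon is drawn S in compound 2 and without a configuration in compound 3. With both drawn forms giving numbers within the scatter of each other, the expected step is a 1.3-fold higher number from compound 2 to compound 3 (0.11 log units; within the scatter), nothing beyond the scatter. For compound 3 the estimate in this assay is 54000 nM, with a range from 30000 nM to 100000 nM.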

Compound 3, half-maximal inhibitory concentration: 225000 nM
Compound 3: the middle estimate sits 4.2-fold (0.62 log units) below what was measured; measured number outside the range, above it.
By their numbers in this assay, from the lowest: compounds 2 and 1 (each within the scatter of the next); then compound 3.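

In this assay, a drawing without configuration does not simply match the two drawn forms: the steps are a 5.4-fold higher number from compound 2 to compound 3 (0.73 log units; beyond the scatter) and a 3.1-fold higher number from compound 1 to compound 3 (0.50 log units; beyond the scatter), although the two mirror images lie within the scatter of each other. The sole difference on one of these steps is stereochemical: the fact that one of compounds 2 and 3 is drawn with a defined configuration and the other without, at the place where they differ The other step has the same kind of difference: the fact that one of compounds 1 and 3 is drawn with a defined configuration and the other without, at the place where they differ

The drawing of compound 3 does not tell which stereo form or forms its sample holds, and the reason for the gap remains unknown. Also open, from the compounds shown here alone, is how the number would respond to an amine or a carboxylic acid in place of a hydroxyl group.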